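The source may report more compounds than this note shows. Statements on the series, on what has been measured and on what is new or still open speak of the compounds shown alone.

Among the compounds with values here, compound 1, `CC(=O)Nc1nc(-c2cccc(NS(=O)(=O)c3cccc(Br)c3)c2)cs1`, is the only member of this set with a measured number: in a functional assay on A-375 cells (Homo sapiens) for antiproliferative activity, read by trypan blue exclusion, with a stated time of 48 h, tested at 10 uM (a higher number here means a weaker effect of the compound at the concentration tested, a lower number a stronger effect), compound 1 gives 36%. Compound 2, `CCCCC#Cc1ccc(S(=O)(=O)Nc2cccc(-c3csc(NC(C)=O)n3)c2)cc1`, reaches in this assay only a limit, < 1%. Compound 3, `CC(=O)Nc1nc(-c2cccc(NS(=O)(=O)c3ccc(C#CCCc4ccccc4)cc3)c2)cs1`, likewise stands at a limit in this assay, < 1%. Within the data shown here, the one change in a single place among the measured compounds, a step that the two limits leave unreadable from compound 2 to compound 3, cannot be read as a size, since the limit of < 1% in this assay, at which 2 of the 3 values shown sit, holds both of its ends. Compound 4, `C#Cc1cccc(S(=O)(=O)Nc2cccc(-c3csc(NC(C)=O)n3)c2)c1`, differs from compound 1 in one place: ethynyl in place of bromo on an aromatic carbon. Among the measured compounds shown here, no measured step touches this particular change, so its size and direction remain open from the steps alone. What the set does show is that the two compounds carrying a triple bond outside the aromatic rings, compound 2 and compound 3, both sit at the limit, whereas compound 1 with bromo does not. On that basis compound 4 is expected to move toward a stronger effect in this assay, though with wide uncertainty. The expected step is a number 18 percentage points lower from compound 1 to compound 4 (beyond the scatter). The value expected for compound 4 in this assay is 18%, between 2% and 45%.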

Compound 4, a percentage reported as activity, at one concentration (the size of the read-out at that concentration, not a potency): 18.6%
Compound 4: middle estimate off by 0.6 percentage points, on the low side; the measured number falls inside the stated range.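

In this assay, within the data shown here, replacing bromo with ethynyl on this aromatic carbon, meta to a large group, gives a number 17.4 percentage points lower from compound 1 to compound 4 (beyond the scatter), the first step in the set whose size can be read. It shows that a triple bond outside the aromatic rings can go with a stronger effect at this position even as a bare ethynyl, with no chain carried behind it. The swap adds no ring, no hydrogen-bond donor or acceptor and no net charge, so the readable difference here is between bromo and ethynyl alone, 3-bromophenyl against 3-ethynylphenyl.

Whether the step belongs to the triple bond itself stays open, since the compounds shown do not say how a nitrile, a methyl or an amine on this same carbon would compare, nor how a longer chain on the ethynyl would fare here. The step from compound 2 to compound 3 also remains unreadable, so what the phenyl adds to the chain cannot be given a size: the limit of < 1% in this assay, at which 2 of the 4 values shown sit.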